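The source may hold more compounds than are shown below. What is called first, only, known or untested is meant among the compounds shown, and "the series" means these compounds.

Compound 1 `O=C(Nc1cc(-c2ccccc2)[nH]n1)c1cccnc1F`: 4880 nM
Compound 2 `O=C(Nc1cc(-c2ccccc2)[nH]n1)c1ccc(Cl)nc1`: 7850 nM

In a functional assay on A-375 cells (Homo sapiens) for antiproliferative activity, read by MTT assay, with a stated time of 48 h (a lower number here means a stronger inhibitor, a higher number a weaker inhibitor), compound 1 gives 4880 nM, the lowest of the two numbers; the nearest is compound 2, with a 1.6-fold higher number from compound 1 to compound 2 (0.21 log units; within the scatter). Compound 3 `Cc1ccc(-c2cc(NC(=O)c3cccnc3F)n[nH]2)cc1` differs from compound 1 by methyl in place of hydrogen on an aromatic carbon, that is phenyl to 4-methylphenyl. Among the compounds with values here, the single measured step, a 1.6-fold higher number from compound 1 to compound 2 (0.21 log units; within the scatter), alters a different part of compound 1 and so does not bear on this methyl; no measured step informs it. For compound 3 the estimate in this assay is therefore a step of a 1.1-fold lower number from compound 1 to compound 3 (0.04 log units; within the scatter), not beyond the scatter, with an expected 4500 nM ranging from 1500 nM to 13000 nM.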

Compound 3, half-maximal inhibitory concentration: 3160 nM
For compound 3 the middle estimate is 1.4-fold (0.15 log units) above the measured one; low and high end bracket the measured number.
By their numbers in this assay, from the lowest: compounds 3, 1 and 2 (each within the scatter of the next, the first and the last beyond it).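

In this assay, the change from phenyl to 4-methylphenyl gives a 1.5-fold lower number from compound 1 to compound 3 (0.19 log units; within the scatter). This shows that a methyl can sit on this aromatic carbon, para to a large group, without a step beyond the scatter, something compound 2 could not show, as it differs from compound 1 in another part. Nothing available explains this result.

The compounds shown leave open whether a longer chain such as ethyl, or an amine, at this place would give a step beyond the scatter. They also leave open whether the methyl would give a similar step alongside the 6-chloropyridin-3-yl group of compound 2.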